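The source may hold more compounds than are shown below. What is called first, only, known or untested is meant among the compounds shown, and "the series" means these compounds.

Measured compounds in a toxicity assay on PC-12 cells (Rattus norvegicus) for cytotoxicity, read by MTT assay; on this read-out lower numbers stand for stronger inhibition and higher numbers for weaker inhibition:
- compound 1 `CC(C)c1ccc(-n2nc(-c3ccc(C(F)(F)F)cc3O)nc2-c2ccccc2O)cc1`: 144000 nM
- compound 2 `Oc1cc(C(F)(F)F)ccc1-c1nc(-c2ccccc2O)n(-c2cccc(C(F)(F)F)c2)n1`: 49700 nM
- compound 3 `COc1cccc(-n2nc(-c3ccc(C(F)(F)F)cc3O)nc2-c2ccccc2O)c1`: 56400 nM

Compound 1 gives the highest of the three numbers in this assay. Its nearest neighbour is compound 3, with a 2.6-fold lower number from compound 1 to compound 3 (0.41 log units; beyond the scatter); the furthest is compound 2, with a 2.9-fold lower number from compound 1 to compound 2 (0.46 log units; beyond the scatter). Between compound 2 and compound 3 the step is a 1.1-fold higher number from compound 2 to compound 3 (0.05 log units; within the scatter), so the two substituted phenyl groups on the aromatic nitrogen cannot be told apart on these numbers.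

Compound 4 `Cc1ccc(-n2nc(-c3ccc(C(F)(F)F)cc3O)nc2-c2ccccc2O)c(C)c1` has not yet been measured. It differs from compound 1 in one place: 2,4-dimethylphenyl in place of 4-isopropylphenyl on an aromatic nitrogen. The two measured steps that bear on this change are the two that also replace the 4-isopropylphenyl on the aromatic nitrogen, a 2.9-fold lower number from compound 1 to compound 2 (0.46 log units; beyond the scatter) and a 2.6-fold lower number from compound 1 to compound 3 (0.41 log units; beyond the scatter), both modest and both toward a lower number. Among the compounds with values here, no measured step shows how an alkyl-substituted phenyl of a different pattern behaves in this position, so the expectation rests on those two steps alone.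

Compound 4 is therefore expected to give a number at or somewhat below that of compound 1, with an estimated step of a 1.7-fold lower number from compound 1 to compound 4 (0.23 log units; within the scatter). The estimate for compound 4 in this assay is 85000 nM, within a range from 40000 nM to 180000 nM.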

Compound 4, half-maximal inhibitory concentration: 231000 nM
Estimate against measurement, compound 4: 2.7-fold (0.43 log units) below, and the stated range ends below it.
By their numbers in this assay, from the lowest: compounds 2 and 3 (each within the scatter of the next); then compounds 1 and 4 (each within the scatter of the next).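

In this assay, 2,4-dimethylphenyl in place of 4-isopropylphenyl on the aromatic nitrogen gives a 1.6-fold higher number from compound 1 to compound 4 (0.21 log units; within the scatter), so replacing the 4-isopropylphenyl does not in itself lower the number, as the two earlier replacements might have suggested. The other two steps to the new compound are a 4.1-fold higher number from compound 3 to compound 4 (0.61 log units; beyond the scatter) and a 4.6-fold higher number from compound 2 to compound 4 (0.67 log units; beyond the scatter), which divides the four compounds into two groups: compounds 1 and 4, with alkyl-substituted phenyl groups, cannot be told apart, and neither can compounds 2 and 3, with 3-(trifluoromethyl)phenyl and 3-methoxyphenyl. Nothing in the available data accounts for this division.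

The compounds shown cannot separate the kind of substituent from its place on the phenyl group, as the two groups differ in both, and a 3-methylphenyl or 3-isopropylphenyl group would bear directly on this. They also leave open how a phenyl group carrying an amine or a carboxylic acid on the aromatic nitrogen would read in this assay.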